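This account rests on a few compounds, and the source may have more. Where it says the series, first, only, none or still open, it means among the compounds named here.

In a functional assay (plasma) for inhibition, with Homo sapiens as the target (on this read-out higher numbers stand for weaker inhibition and lower numbers for stronger inhibition), compound 1 (`CCCCCCOC[C@@H]1C2CCC(O2)[C@@H]1C/C=C\CCCC(=O)O`) has two entries, 38500 nM; 10000 nM (2 entries). Within the data shown here, compound 2 (`CCCCCCCO[C@H]1C2CCC(O2)[C@@H]1C/C=C\CCCC(=O)O`) gives 120000 nM, its only number in this assay, as one further entry for it carries no single number. This value is a higher number than either entry of compound 1, so compound 2 stands on the weaker side of the two compounds. Compound 3 (`CCCCCCCO[C@@H]1C2CCC(O2)[C@@H]1C/C=C\CCCC(=O)O`) has the same atoms and bonds as compound 2. The change is the two compounds have the same atoms and bonds; at least one stereo element is drawn with a configuration in one of them and without one in the other: 1 of 5 stereo elements differ; a stereocentre at a saturated ring carbon is drawn R in compound 2 and S in compound 3: a stereocentre at a saturated ring carbon is drawn R in compound 2 and S in compound 3. Among the measured compounds shown here, no measured pair shows such a change. Compound 1, at 38500 nM; 10000 nM (2 entries), shows that lower numbers occur with a closely related structure, so a modest move toward stronger inhibition is expected. The expected change is a 2.4-fold lower number from compound 2 to compound 3 (0.38 log units; beyond the scatter), though its size is uncertain. For compound 3 the estimated value is 50000 nM, with an expected range from 12000 nM to 200000 nM.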

Compound 3, half-maximal inhibitory concentration: 340000 nM
Beside the measured number, compound 3's estimate is 6.8-fold (0.83 log units) below it; the whole stated range lies below it.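

With the atoms and bonds unchanged, the move from R to S at a stereocentre at a saturated ring carbon gives a 2.8-fold higher number from compound 2 to compound 3 (0.45 log units; beyond the scatter) in this assay. Among these compounds, this is the first single-place change, and it shows that this one ring carbon affects the read-out on its own, with S going with weaker inhibition than R in this pair. The comparison rests on one pair, and its reading as a clean exchange of R for S carries a caveat: the fact that one of compounds 2 and 3 is drawn with a defined configuration and the other without, at the place where they differ

The compounds shown leave open whether the same preference would hold with a longer chain, or with a tetrazole in place of the carboxylic acid. They also leave open how the other stereo elements of the shared core bear on the read-out, since only this one differs here.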